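Compound 3: will clearance stay at the limit?

The source may report more compounds than this note shows. Statements on the series, on what has been measured and on what is new or still open speak of the compounds shown alone.

- compound 1 `Nc1ccc(S(=O)(=O)N2CCN(c3ncc(C(O)(C(F)(F)F)C(F)(F)F)cc3-c3ccoc3)CC2)cn1`: < 14 mL.min-1.g-1
- compound 2 `Nc1ccc(S(=O)(=O)N2CCN(c3ncc(C(O)(C(F)(F)F)C(F)(F)F)cc3-c3ccc4c(c3)CC(=O)N4)CC2)cn1`: < 14 mL.min-1.g-1

Both results come from an ADME assay (liver) for metabolic stability, with Liver microsome (Homo sapiens) as the target, using microsomes and NADPH, with a stated time of 30 min, tested at 1 uM; a lower number here means slower removal, a higher number faster removal of the compound. Compound 2 gives < 14 mL.min-1.g-1, which is a limit of the assay and not a number. It shares that position with compound 1: the limit of < 14 mL.min-1.g-1 in this assay, at which 2 of the 2 values shown sit.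

Compound 3 `Nc1ccc(S(=O)(=O)N2CCN(c3ncc(C(O)(C(F)(F)F)C(F)(F)F)cc3-c3cccc4[nH]ncc34)CC2)cn1` has not been measured. It differs from compound 2 by one group: a group of 9 heavy atoms (7 carbon, 2 nitrogen; one five-membered aromatic ring with 2 hetero atoms, one six-membered aromatic ring of carbon only) in place of a group of 10 heavy atoms (8 carbon, 1 nitrogen, 1 oxygen; one five-membered non-aromatic ring with 1 hetero atom, one six-membered aromatic ring of carbon only), on an aromatic carbon. The 1H-indazol-4-yl group sits on an aromatic carbon, ortho to a large group.

Going by the values given here, the one measured step bearing on this is also a group swap on an aromatic carbon: a step that the two limits leave unreadable from compound 1 to compound 2. Its size cannot be read, so it offers no sign of a shift, and no change beyond the usual scatter is expected in this assay. The expected change is a step that the limit leaves unreadable from compound 2 to compound 3. For compound 3 the estimated value is 12 mL.min-1.g-1, with an expected range from 8 mL.min-1.g-1 to 22 mL.min-1.g-1.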

Compound 3, intrinsic clearance in microsomes: 42 mL.min-1.g-1
Estimate against measurement, compound 3: 3.5-fold (0.54 log units) below, outside the stated range (above it).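

Changing the group at this place, ortho to a large group, can shift the read-out in this assay: 1H-indazol-4-yl gives an at least 3.0-fold higher number from compound 2 to compound 3 (0.47 log units; beyond the scatter), and in place of furan-3-yl it gives an at least 3.0-fold higher number from compound 1 to compound 3 (0.47 log units; beyond the scatter). Compound 3 is the only compound shown that stands clear of the limit shared by the other two: the limit of < 14 mL.min-1.g-1 in this assay, at which 2 of the 3 values shown sit. The step from compound 1 to compound 2 cannot be read, so the readable change at this position appears only with compound 3.

The compounds shown leave open how far compound 1 and compound 2 lie under their limit, and so the full size of both steps. They also leave open whether a plain phenyl ring or a 1H-indol-4-yl group at the same place would stay at the limit or rise as compound 3 does.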